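Trading a methoxymethyl for a vinyl on the amide side chain

The compounds below may be only part of what the source reports. "The series", "measured", "known", "first", "only" and "open" are said of these compounds alone.

Compound 1 `C=CCN(CCOC)C(=O)[C@@]1(c2ccsc2)C[C@H]1CN` gives > 10000 nM in an assay on HEK293 cells for inhibition of sodium-dependent dopamine transporter (Homo sapiens) (a higher number here means a weaker inhibitor, a lower number a stronger inhibitor), which is a limit of the assay and not a number. Compound 2 `COCCN(C)C(=O)[C@@]1(c2ccsc2)C[C@H]1CN` gives > 10000 nM in this assay, again only a limit.

From the compounds shown here alone, compound 2 thus stands at the limit of > 10000 nM in this assay, at which 2 of the 2 values shown sit, so its true strength is unknown. The step that the two limits leave unreadable from compound 1 to compound 2 cannot be read, as both values are limits. Compound 3 `C=CCN(C)C(=O)[C@@]1(c2ccsc2)C[C@H]1CN` differs from compound 2 by vinyl in place of methoxymethyl on a saturated chain carbon bound to an amide-type nitrogen. No readable measured step bears on this change. Compound 3 is therefore expected to stay weak, with the step that the limit leaves unreadable from compound 2 to compound 3 expected to be small. Compound 3 is estimated at 15000 nM, within 3000 nM to 60000 nM.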

Compound 3, half-maximal inhibitory concentration: > 10000 nM
Compound 3: a limit, no number; the forecaster's own chance of this, stated with the estimate: 75%; the middle value does not contradict the limit.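

In this assay compound 3 gives > 10000 nM, a limit and not a number. Within the data shown here, no step among compound 1, compound 2 and compound 3 can be read. The compounds shown leave open how strongly each one truly inhibits, and whether vinyl in place of methoxymethyl changes anything.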